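A few compounds are considered here, and "the series" means these few. Any claim that something is new, unique, unknown or untested is made for them only; others in the source may bear on it.

Measured in an ADME assay on microsomes from liver (Rattus norvegicus) for metabolic stability; a higher number here means that more of the compound is left, a lower number that less of the compound is left:
- compound 1 `N[C@H]1CC[C@H](CN(C[C@H]2Cc3ccccc3CN2)[C@H]2CCCc3cccnc32)CC1`: 51%
- compound 2 `C/C(CN(C[C@H]1Cc2ccccc2CN1)[C@H]1CCCc2cccnc21)=C(/F)CN`: 61%

In this assay, among the compounds with values here, compound 1 gives 51%, a number within the scatter of its only neighbour, compound 2.

Compound 3 `C/C(CN(C[C@H]1Cc2ccccc2CN1)[C@H]1CCCc2cccnc21)=C(\F)CN` has not been measured. Its structural change from compound 1 is 3-amino-2-fluoro-1-methylprop-1-en-1-yl in place of 4-aminocyclohexyl on a saturated chain carbon bound to an amine nitrogen. It puts 3-amino-2-fluoro-1-methylprop-1-en-1-yl in place of 4-aminocyclohexyl on a saturated chain carbon bound to an amine nitrogen.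

Within the data shown here, the one measured step bearing on this is a number 10 percentage points higher from compound 1 to compound 2 (within the scatter). It brings in a group of the same name at the same place. A single step of this size gives little to go on, so no change beyond the scatter is expected.

The estimated step is a number 6 percentage points higher from compound 1 to compound 3 (within the scatter).

Compound 3 is expected at 57%, with an estimated range of 43% to 71%.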

Compound 3, percent of the compound remaining: 6%
Estimate against measurement, compound 3: 51 percentage points above; measured number below the stated range.
By their numbers in this assay, from the lowest: compound 3; then compounds 1 and 2 (each within the scatter of the next).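

In this assay, 3-amino-2-fluoro-1-methylprop-1-en-1-yl in place of 4-aminocyclohexyl on a saturated chain carbon bound to an amine nitrogen is not a uniformly tolerated change: the drawn E form gives a number 45 percentage points lower from compound 1 to compound 3 (beyond the scatter). The outcome at this position therefore depends on more than the group's name, and the Z and E forms are far apart: a number 55 percentage points lower from compound 2 to compound 3 (beyond the scatter). This gap can be assigned to the double-bond configuration as drawn because of one fact: the fact that compounds 2 and 3 differ only in the configuration as drawn

As far as these compounds go, whether the same gap between Z and E forms would persist with hydrogen in place of the fluorine, or with a dimethylamino group in place of the primary amine, remains open. The numbers also leave open which part of compound 3 is lost in the microsomal incubation.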